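A few compounds are considered here, and "the series" means these few. Any claim that something is new, unique, unknown or untested is made for them only; others in the source may bear on it.

Compound 1, `C/C(=C1/OC(=O)NC1=O)C(c1ccc(-c2ccc3cccc(F)c3c2)[nH]c1=O)C(C)C`: in an ADME assay on microsomes from liver (Homo sapiens) for metabolic stability (on this read-out higher numbers stand for a longer-lived compound and lower numbers for a shorter-lived compound), compound 1 gives > 3 h, which is a limit of the assay.
Compound 2, `CC(C)C(c1ccc(-c2ccc3cccc(F)c3c2)[nH]c1=O)C1C(=O)NC(=O)N1C`: in this assay compound 2 gives 0.375 h.
Compound 3, `CC(C)C(/C=C1/C(=O)NC(=O)N1C)c1ccc(-c2ccc3cccc(F)c3c2)[nH]c1=O`: in this assay compound 3 gives > 3 h, which is a limit of the assay.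

Compound 3 therefore sits at the limit of > 3 h in this assay, at which 2 of the 3 values shown sit, and only a limit is known for it. The step of an at least 8.0-fold higher number from compound 2 to compound 3 (0.90 log units; beyond the scatter) is the one that bears on the next change. Compound 4, `CC(C)C(CC1C(=O)NC(=O)N1C)c1ccc(-c2ccc3cccc(F)c3c2)[nH]c1=O`, differs from compound 3 as follows: a group of 9 heavy atoms (5 carbon, 2 nitrogen, 2 oxygen; one five-membered non-aromatic ring with 2 hetero atoms) in place of a group of 9 heavy atoms (5 carbon, 2 nitrogen, 2 oxygen; one five-membered non-aromatic ring with 2 hetero atoms), on a saturated chain carbon bound to an aromatic carbon and a saturated chain carbon. The group entering has 2 double bonds outside aromatic rings where the group leaving had 3, so compound 4 moves back towards the kind of attachment seen in compound 2, whose number was far lower than that of compound 3. A fall is therefore expected for compound 4 in this assay, an at least 3.0-fold lower number from compound 3 to compound 4 (0.47 log units; beyond the scatter), though not necessarily all the way down to compound 2. Compound 4 is estimated at 1 h, within a range of 0.3 h to 3 h.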

Compound 4, half-life in the Homo sapiens assay: 0.153 h
Compound 4: middle estimate off by 6.5-fold (0.82 log units), on the high side; measured number outside the range, below it.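

In the Homo sapiens assay, removing one double bond outside aromatic rings while keeping the heavy-atom count unchanged gives an at least 19-fold lower number from compound 3 to compound 4 (1.29 log units; beyond the scatter), and the comparison with the oxygen-containing ring gives an at least 19-fold lower number from compound 1 to compound 4 (1.29 log units; beyond the scatter). In the Homo sapiens assay, putting (3-methyl-2,5-dioxoimidazolidin-4-yl)methyl in place of 3-methyl-2,5-dioxoimidazolidin-4-yl gives a 2.5-fold lower number from compound 2 to compound 4 (0.39 log units; beyond the scatter), so among these compounds only the two with a double bond linking ring and chain, compound 1 and compound 3, reach the limit: the limit of > 3 h in the Homo sapiens assay, at which 2 of the 4 values shown sit. In a physicochemical assay for solubility, in phosphate buffer, measured as kinetic solubility (on this read-out lower numbers stand for lower solubility and higher numbers for higher solubility), compound 3 gives 34800 nM and compound 4 gives 33600 nM, values within the usual scatter of each other, so this change separates half-life from solubility.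

Because compound 1 and compound 3 both stand at a limit, the step between them cannot be read. Going by these compounds, whether a longer chain or an amine in place of the ring would change the half-life remains open.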